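Working notes: from compound 3 to compound 4

A few compounds are considered here, and "the series" means these few. Any claim that something is new, unique, unknown or untested is made for them only; others in the source may bear on it.

In a functional assay on the whole organism (strain Kunming) with Mus musculus as the target, with a stated time of 0.5 h (a lower number here means that less compound is needed, a higher number that more compound is needed for the effect), compound 1 `COc1ccccc1/C=C/C(=O)OC/C=C/c1cc(OC)c(OC)cc1OC` gives 625 umol/kg, and compound 2 `COc1cc(OC)c(OC)cc1/C=C/COC(=O)/C=C/c1ccc(Br)cc1` gives 446 umol/kg. From the compounds shown here alone, compound 3 `COc1cc(OC)c(OC)cc1/C=C/COC(=O)/C=C/c1ccccc1C(F)(F)F` is reported only as a limit, > 473 umol/kg, so its exact place stays open.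

Compound 4 `COc1cc(OC)c(OC)cc1/C=C/COC(=O)/C=C/c1cccc(Br)c1` carries 3-bromophenyl in place of 2-(trifluoromethyl)phenyl, on a double-bonded chain carbon bound to a double-bonded chain carbon (3-bromophenyl in place of 2-(trifluoromethyl)phenyl on a double-bonded chain carbon bound to a double-bonded chain carbon).

The measured step closest to this change, an at least 1.0-fold higher number from compound 2 to compound 3 (0.02 log units; that floor lies within the scatter), swaps 4-bromophenyl for 2-(trifluoromethyl)phenyl, and its floor lies within the scatter. The step of a 1.4-fold lower number from compound 1 to compound 2 (0.15 log units; within the scatter) is also within the scatter, while a step that the limit leaves unreadable from compound 1 to compound 3 cannot be sized. For the measured compounds named here, no measured step in this small set goes beyond the scatter, so no change beyond it can be firmly expected, and no direction is favoured. The expectation rests mainly on compound 2 at 446 umol/kg, which also carries a bromophenyl group.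

The expected step is a number no higher from compound 3 to compound 4 (the limit leaves the size open). For compound 4 the estimated value is 470 umol/kg, with an expected range of 260 umol/kg to 850 umol/kg.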

Compound 4, dose for half-maximal effect: > 461 umol/kg
Compound 4 was reported as a limit; the forecaster's own chance of this, stated with the estimate: 30%; the middle value is on the limit's open side.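

In this assay compound 4 is reported only as a limit: the limit of > 461 umol/kg in this assay, at which 1 of the 4 values shown sits.

For the compounds shown here, the one readable step is an at least 1.0-fold higher number from compound 2 to compound 4 (0.01 log units; that floor lies within the scatter). This floor shows no step beyond the scatter for 3-bromophenyl in place of 4-bromophenyl on a double-bonded chain carbon bound to a double-bonded chain carbon, and it leaves the true size open. The steps to compound 4 from compound 3 and from compound 1 cannot be read.

The compounds shown leave open how far the true values of compound 3 and compound 4 lie past their limits, and so whether the place of the bromine on the phenyl ring matters at all. They also leave open how this place responds to a phenyl ring carrying an amine or a carboxylic acid.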